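The compounds below may be only part of what the source reports. "The series", "measured", "known", "first", "only" and "open" are said of these compounds alone.

Measured compounds in an assay for inhibition of Fatty-acid amide hydrolase 1 (Rattus norvegicus); a higher number here means a weaker inhibitor, a lower number a stronger inhibitor:
compound 1, `O=C(O)c1cccc(CCCCCCC(=O)c2ncc(-c3ccccn3)o2)c1`: > 600 nM
compound 2, `CS(=O)(=O)c1ccccc1CCCCCCC(=O)c1ncc(-c2ccccn2)o1`: 37 nM

Two compounds of the series carry a number or limit so far. Going by the values given here, compound 1, bearing 3-carboxyphenyl at the chain end, gives in this assay only a limit, > 600 nM; this is the one value sitting at the limit of > 600 nM in this assay, at which 1 of the 2 values shown sits. Compound 2, with a methylsulfonylphenyl on the same chain, gives 37 nM in this assay. Among the compounds with values here, the two compounds differ in more than one place, so the pair shows only that compound 2 reaches a number where compound 1 does not.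

Compound 3, `COc1ccc(CCCCCCC(=O)c2ncc(-c3ccccn3)o2)cc1`, is not yet measured. It differs from compound 1 by 4-methoxyphenyl in place of 3-carboxyphenyl on a saturated chain carbon, six bonds along the chain from a carbonyl carbon. Within the data shown here, no measured step of one place stands beside this change. Given that compound 1 sits at the limit of > 600 nM in this assay, at which 1 of the 2 values shown sits, while compound 2 gives 37 nM, the step from compound 1 to compound 3 is expected at an at least 12-fold lower number from compound 1 to compound 3 (1.07 log units; beyond the scatter), towards stronger inhibition and beyond the scatter. Compound 3 is estimated at 50 nM, within 15 nM to 200 nM.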

Compound 3, inhibition constant: 6.2 nM
Compound 3: the middle estimate sits 8.1-fold (0.91 log units) above what was measured; measured number outside the range, below it.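

In this assay, the saturated chain carbon six bonds along the chain from a carbonyl carbon proves highly sensitive to the group it carries: 4-methoxyphenyl in place of 3-carboxyphenyl gives an at least 96-fold lower number from compound 1 to compound 3 (1.98 log units; beyond the scatter). This single change carries the series from a limit to a measured number, which the earlier pair, differing in more than one place, could not tie to one place. The step is only a minimum because compound 1 carries a limit and not a number: the limit of > 600 nM in this assay, at which 1 of the 3 values shown sits.

The change removes the carboxylic acid, adds the methoxy group and moves the place of the group on the phenyl ring all at once, and the compounds shown do not separate these three. From the compounds shown here alone, an unsubstituted phenyl or a methyl ester at the chain end would begin to tell them apart, and the effect of a shorter chain also remains open.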